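Chloro for Nitrile on the Benzyl Arm

The source may hold more compounds than are shown below. What is called first, only, known or untested is meant among the compounds shown, and "the series" means these compounds.

In a functional assay on NIH3T3 cells (Mus musculus) (on this read-out higher numbers stand for an effect only at larger amounts of compound and lower numbers for an effect already at smaller amounts), compound 2 `CSCC[C@H](NC(=O)c1ccc(NCc2cncn2Cc2cccc(C#N)c2)cc1-c1ccccc1)C(=O)O` reaches only the limit of the assay, > 10 uM, so its place on the scale is not a number. Compound 1 `COC(=O)[C@H](CCSC)NC(=O)c1ccc(NCc2cncn2Cc2ccc(Cl)cc2)cc1-c1ccccc1` likewise sits at the limit of this assay, > 10 uM. Among the compounds with values here, both values shown thus rest at the same limit, (the limit of > 10 uM in this assay, at which 2 of the 2 values shown sit), and no step between measured compounds can be drawn. Compound 3 `CSCC[C@H](NC(=O)c1ccc(NCc2cncn2Cc2ccc(Cl)cc2)cc1-c1ccccc1)C(=O)O` is the still unmeasured partner of compound 2; the change is 4-chlorophenyl in place of 3-cyanophenyl on a saturated chain carbon bound to an aromatic nitrogen. Within the data shown here, compound 1 already carries the 4-chlorobenzyl arm and stands at the limit, so nothing among the measured compounds points toward a gain in potency from this exchange. The step from compound 2 to compound 3 is therefore expected to be a step that the limit leaves unreadable from compound 2 to compound 3, nothing beyond the usual scatter. Compound 3 is estimated at 15 uM, within a range of 5 uM to 50 uM, with a considerable chance that this assay again reports only a limit.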

Compound 3, concentration for half-maximal effect: > 10 uM
Compound 3 gave a limit, no number; the forecaster's own chance of this, stated with the estimate: 75%; the middle value does not contradict the limit.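

In this assay compound 3 gives > 10 uM, a limit of the assay and not a number. Within the data shown here, no step linking compound 3 to compound 1 or compound 2 can be read, because all the values rest at one limit: the limit of > 10 uM in this assay, at which 3 of the 3 values shown sit. The compounds shown leave open whether either exchange, on the benzyl arm or on the oxygen next to the carbonyl group, changes potency in this assay.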